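Working notes: trifluoromethyl in place of hydrogen

The source may report more compounds than this note shows. Statements on the series, on what has been measured and on what is new or still open speak of the compounds shown alone.

- compound 1 `COc1cc(-n2cnc3ccc(-c4ccc([N+](=O)[O-])cc4)cc32)cc(OC)c1OC`: 79 nM
- compound 2 `COc1cc(-n2cnc3ccc(-c4ccccc4)cc32)cc(OC)c1OC`: 290 nM

Both values come from a functional assay on SGC-7901 cells (Homo sapiens) for antiproliferative activity, read by MTT assay, with a stated time of 72 h; a lower number here means a stronger inhibitor, a higher number a weaker inhibitor. Within the data shown here, compound 2, at 290 nM, holds the higher number of the two, and its only neighbour is compound 1 at 79 nM.

The next change leads to compound 3 `COc1cc(-n2cnc3ccc(-c4ccc(C(F)(F)F)cc4)cc32)cc(OC)c1OC`: trifluoromethyl in place of hydrogen on an aromatic carbon. Among the measured compounds shown here, one measured step bears on it, at the same carbon: a 3.7-fold higher number from compound 1 to compound 2 (0.56 log units; beyond the scatter), with hydrogen in place of nitro. Read backwards, that step shows a substituent there going with the lower number, but a single pair says nothing directly about trifluoromethyl. A modest move toward a lower number in this assay is therefore expected, smaller than the nitro step and possibly close to the scatter. The expected change is a 2.1-fold lower number from compound 2 to compound 3 (0.32 log units; beyond the scatter). For compound 3 the estimated value is 140 nM, with an expected range of 55 nM to 350 nM.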

Compound 3, half-maximal inhibitory concentration: 890 nM
Compound 3: middle estimate off by 6.4-fold (0.80 log units), on the low side, outside the stated range (above it).
By their numbers in this assay, from the lowest: compound 1; then compound 2; then compound 3.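

In this assay, a substituent at this carbon does not by itself go with the lower number: trifluoromethyl in place of hydrogen gives a 3.1-fold higher number from compound 2 to compound 3 (0.49 log units; beyond the scatter), the opposite direction to the nitro comparison. Against nitro, the same group gives an 11-fold higher number from compound 1 to compound 3 (1.05 log units; beyond the scatter), so the order at this carbon runs from nitro through hydrogen to trifluoromethyl, and the direction of a change depends on which group enters. Nothing measured in the data at hand accounts for the gap between these two groups.

Where an amine, a nitrile or a carboxylic acid at this carbon would fall in that order remains open. Also open, on these data alone, is whether the order of the three compounds holds on any other cell line or on the shared core with a different substituent pattern.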